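The source may hold more compounds than are shown below. What is called first, only, known or untested is meant among the compounds shown, and "the series" means these compounds.

Compound 1 `[N-]=[N+]=NC[C@H]1O[C@H](CO)[C@@H](O)[C@H](O)[C@H]1O` gives 25100000 nM in an assay on isolated protein (Sus scrofa) for inhibition of glycogen phosphorylase, brain form (Homo sapiens) (on this read-out lower numbers stand for stronger inhibition and higher numbers for weaker inhibition), the highest of the three numbers in hand. Compound 2 `[N-]=[N+]=NC[C@@H]1O[C@H](CO)[C@@H](O)[C@H](O)[C@H]1O` gives 15800000 nM and compound 3 `O=C(Nc1ccccc1)[C@H]1O[C@H](CO)[C@@H](O)[C@H](O)[C@H]1O` gives 12600000 nM. For the measured compounds named here, the one counted step, a 1.6-fold lower number from compound 1 to compound 2 (0.20 log units; within the scatter), comes with the fact that one of compounds 1 and 2 is drawn with a defined configuration and the other without, at the place where they differ. Going by the values given here, no measured step bears directly on the change to compound 4 `NC(=O)N[C@H]1O[C@H](CO)[C@@H](O)[C@H](O)[C@H]1O`, which is ureido in place of azidomethyl on a saturated ring carbon. All three numbers in this assay sit within the scatter of one another, so no step beyond it is expected from this change. Compound 4 is therefore estimated at 10000000 nM, between 1000000 nM and 30000000 nM. The expected step of a 2.5-fold lower number from compound 1 to compound 4 (0.40 log units; beyond the scatter) is small and carries wide uncertainty.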

Compound 4, inhibition constant: 126000 nM
Compound 4: the middle estimate sits 79-fold (1.90 log units) above what was measured; measured number below the stated range.
By their numbers in this assay, from the lowest: compound 4; then compounds 3, 2 and 1 (each within the scatter of the next).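

The step of a 200-fold lower number from compound 1 to compound 4 (2.30 log units; beyond the scatter) shows that this position can respond strongly to the group it carries, which compounds 1, 2 and 3, all within the scatter of one another, did not reveal. Ureido and azidomethyl match in heavy atoms but differ in hydrogen-bond donors, though this count alone does not establish why the number moved. Nothing on record accounts for this step.

From the compounds shown here alone, it remains open which part of ureido matters. An amine, an acetamido group or a methylureido group at this position would help to separate the possibilities.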